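Replacing the 3-sulfamoylphenyl group of compound 2

The source may hold more compounds than are shown below. What is called first, only, known or untested is meant among the compounds shown, and "the series" means these compounds.

Measured so far in an ADME assay on LLC-MK2 cells (Macaca mulatta) for cytotoxicity, read by spectrophotometry and crystal violet staining, with a stated time of 4 days; a higher number here means that more compound is tolerated, a lower number that less compound is tolerated:
Compound 1 `CC(C)n1ncc2c(C(=O)Nc3cccc(F)c3)cc(-c3cccs3)nc21` gives > 200000 nM as a limit
Compound 2 `CC(C)n1ncc2c(C(=O)Nc3cccc(S(N)(=O)=O)c3)cc(-c3cccs3)nc21` gives 25000 nM as a number

Going by the values given here, compound 2 at 25000 nM holds the only actual number in this assay so far. For compound 1 there is only the limit of > 200000 nM in this assay, at which 1 of the 2 values shown sits, to go on. Compound 3 `CC(C)n1ncc2c(C(=O)Nc3ccncn3)cc(-c3cccs3)nc21` is still to be measured. It has pyrimidin-4-yl in place of 3-sulfamoylphenyl on an amide-type nitrogen. Among the compounds with values here, the one measured step that bears on this change put sulfamoyl in place of fluoro on an aromatic carbon. Compound 3 carries no sulfamoyl, so given an at least 8.0-fold lower number from compound 1 to compound 2 (0.90 log units; beyond the scatter) a higher number than for compound 2 is expected. Within the data shown here, no measured step covers pyrimidin-4-yl, so a move of similar or smaller size is expected. The expected step is a 3.6-fold higher number from compound 2 to compound 3 (0.56 log units; beyond the scatter) in this assay overall. For compound 3 the estimate is 90000 nM, with an expected range from 30000 nM to 200000 nM overall.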

Compound 3, half-maximal cytotoxic concentration: 50000 nM
Compound 3: middle estimate off by 1.8-fold (0.26 log units), on the high side; the range from low to high includes it.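

In this assay, pyrimidin-4-yl in place of 3-sulfamoylphenyl on the amide-type nitrogen gives a 2.0-fold higher number from compound 2 to compound 3 (0.30 log units; within the scatter), so losing the sulfamoyl group here does not bring a number that can be told apart from the sulfamoyl compound. Pyrimidin-4-yl in place of 3-fluorophenyl at the same place gives an at least 4.0-fold lower number from compound 1 to compound 3 (0.60 log units; beyond the scatter), which shows that a lower number than that of the fluoro compound does not require sulfamoyl. The size of that step stays open-ended, as compound 1 has only a limit and not a number: the limit of > 200000 nM in this assay, at which 1 of the 3 values shown sits.

The compounds shown leave open how far the number at this place follows the ring itself and how far it follows what the ring carries. A plain phenyl, a pyridinyl ring, or a phenyl bearing an amine or a carboxylic acid could begin to separate the two.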